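Adding 2-hydroxyethyl to compound 3: working notes

This account rests on a few compounds, and the source may have more. Where it says the series, first, only, none or still open, it means among the compounds named here.

In a functional assay on HepG2 cells (Homo sapiens) for antiproliferative activity, read by MTT assay, with a stated time of 72 h (a higher number here means a weaker inhibitor, a lower number a stronger inhibitor), compound 1 `CC(C)(C)c1cn(C[C@H](O)[C@H]2OC(=O)C(OCc3ccccc3)=C2OCc2ccccc2)nn1` gives 29200 nM and compound 2 `O=C1O[C@H]([C@@H](O)Cn2cc(-c3cc(F)cc(F)c3)nn2)C(OCc2ccccc2)=C1OCc1ccccc1` gives 11600 nM, which is a 2.5-fold lower number from compound 1 to compound 2 (0.40 log units; beyond the scatter). Compound 3 `O=C1O[C@H]([C@@H](O)Cn2ccnn2)C(OCc2ccccc2)=C1OCc1ccccc1` gives > 100000 nM, which is a limit of the assay and not a number. It is the only such result so far: the limit of > 100000 nM in this assay, at which 1 of the 3 values shown sits.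

Compound 4 `O=C1O[C@H]([C@@H](O)Cn2cc(CCO)nn2)C(OCc2ccccc2)=C1OCc1ccccc1` has 2-hydroxyethyl in place of hydrogen on an aromatic carbon. Among the compounds with values here, two measured steps bear on this change, since both compare hydrogen with a larger group at that carbon. With hydrogen in place of tert-butyl, the data show an at least 3.4-fold higher number from compound 1 to compound 3 (0.53 log units; beyond the scatter). With hydrogen in place of 3,5-difluorophenyl, they show an at least 8.6-fold higher number from compound 2 to compound 3 (0.93 log units; beyond the scatter). Read in reverse, both steps favour a lower number in this assay once a group enters, although the limit on compound 3 leaves their true sizes open. Neither group is a close match for 2-hydroxyethyl, which has no ring and brings a hydrogen-bond donor, so the transfer is uncertain. An estimated at least 1.6-fold lower number from compound 3 to compound 4 (0.22 log units; that floor lies within the scatter) is expected, and another result at the limit remains quite possible. For compound 4 the expected value is 60000 nM, with an estimated range from 25000 nM to 100000 nM.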

Compound 4, half-maximal inhibitory concentration: 68100 nM
Compound 4: the middle estimate sits 1.1-fold (0.05 log units) below what was measured; the range from low to high includes it.
By their numbers in this assay, from the lowest: compound 2; then compound 1; then compound 4. At a limit, above all of these: compound 3.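

Against hydrogen at this aromatic carbon, 2-hydroxyethyl gives an at least 1.4-fold lower number from compound 3 to compound 4 (0.16 log units; that floor lies within the scatter) in this assay, so this is the first step from compound 3 to a group with a hydrogen-bond donor, and its floor does not establish a gain. The value of compound 3 remains a limit of the assay and not a number: the limit of > 100000 nM in this assay, at which 1 of the 4 values shown sits. Among the groups that give a measured number at this carbon, the identity of the group matters, with 2-hydroxyethyl in place of 3,5-difluorophenyl giving a 5.9-fold higher number from compound 2 to compound 4 (0.77 log units; beyond the scatter), and 2-hydroxyethyl in place of tert-butyl giving a 2.3-fold higher number from compound 1 to compound 4 (0.37 log units; beyond the scatter), so having a group at this position does not by itself reach the numbers of compound 1 and compound 2.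

The compounds shown leave open whether the hydroxyl of 2-hydroxyethyl or its carbon chain sets the number of compound 4, a question that a plain ethyl group on the same aromatic carbon would separate. They also leave open how a longer chain such as 3-hydroxypropyl, or a 2-aminoethyl group, would read in this assay.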